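The source may report more compounds than this note shows. Statements on the series, on what has been measured and on what is new or still open speak of the compounds shown alone.

Measured in an ADME assay on BHK cells (Mesocricetus auratus) for cytotoxicity, read by MTT assay, with a stated time of 96 h; a lower number here means that less compound is tolerated, a higher number that more compound is tolerated:

- Compound 1 `FC(F)(F)c1cccc(NC(=S)Nc2ccc(Cl)cc2)c1`: 10000 nM
- Compound 2 `O=[N+]([O-])c1ccc(NC(=S)Nc2cccc(C(F)(F)F)c2)cc1`: 9500 nM
- Compound 3 `CCCC[C@H]1CC[C@H](c2ccc(NC(=S)Nc3cccc(C(F)(F)F)c3)cc2)CC1`: 9500 nM

In this assay, compound 3 gives 9500 nM, the same number as compound 2 and within the scatter of compound 1. The next compound, compound 4 `N#Cc1ccc(NC(=S)Nc2cccc(C(F)(F)F)c2)cc1`, has not yet been measured. It carries cyano in place of 4-butylcyclohexyl on an aromatic carbon.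

The measured steps all concern this same place on the molecule. The exchange of chloro for nitro gives a 1.1-fold lower number from compound 1 to compound 2 (0.02 log units; within the scatter), chloro for 4-butylcyclohexyl gives a 1.1-fold lower number from compound 1 to compound 3 (0.02 log units; within the scatter), and nitro for 4-butylcyclohexyl gives no change at the digits printed from compound 2 to compound 3 (within the scatter). The three compounds thus tolerate very different groups there without a step beyond the scatter, although cyano itself has not been tested. The expected result is no change at the digits printed from compound 3 to compound 4 (within the scatter), which would be no step beyond the scatter in this assay. Compound 4 is estimated at 9500 nM, with an expected range from 5000 nM to 20000 nM.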

Compound 4, half-maximal cytotoxic concentration: 9500 nM
Compound 4: the middle estimate sits on the measured number at the digits printed; the range from low to high includes it.
By their numbers in this assay, from the lowest: compounds 2, 3, 4 and 1 (each within the scatter of the next).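

In this assay cyano fits in with the three earlier groups at this place, on an aromatic carbon para to a large group: the steps are no change at the digits printed from compound 3 to compound 4 (within the scatter) and no change at the digits printed from compound 2 to compound 4 (within the scatter) and a 1.1-fold lower number from compound 1 to compound 4 (0.02 log units; within the scatter). The exchange takes out 4-butylcyclohexyl, with its non-aromatic ring and its stereocentres, and brings in a group with no ring, a triple bond and a hydrogen-bond acceptor, yet no step beyond the scatter appears, so all four compounds now stand within the scatter of one another. Nothing given here accounts for this flat result.

Going by these compounds, whether an amine or a carboxylic acid at this place would give a step beyond the scatter stays open. So does how the number responds to a change of the trifluoromethyl group common to all four compounds.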